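One Substituent Swap on a Series Level at the Digits Printed

The compounds below may be only part of what the source reports. "The series", "measured", "known", "first", "only" and "open" are said of these compounds alone.

Three compounds have been tested in an assay on CHO cells for displacement of a labelled ligand from adenosine receptor A3 (Homo sapiens), read by scintillation counting, tested at 10 uM; on this read-out lower numbers stand for less inhibition and higher numbers for more inhibition at the one concentration tested (going by the name of the read-out):

compound 1 `CC(C)(C)Cc1c(-c2ccc(Cl)c(Cl)c2)sc(N)c1C(=O)c1ccc(Cl)cc1` gives 1%
compound 2 `COCCOc1ccc(-c2sc(N)c(C(=O)c3ccc(Cl)cc3)c2CC(C)(C)C)cc1` gives 1%
compound 3 `CC(C)(C)Cc1c(-c2ccc(OC(F)(F)F)cc2)sc(N)c1C(=O)c1ccc(Cl)cc1` gives 1%

Compound 3 stands level with compound 1 and compound 2 in this assay; all three values sit within the scatter of one another. For the measured compounds named here, the only comparable step so far, no change at the digits printed from compound 2 to compound 3 (within the scatter), swapped one group on the oxygen of the same aromatic ring and moved nothing.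

Compound 4 `Cc1ccc(-c2sc(N)c(C(=O)c3ccc(Cl)cc3)c2CC(C)(C)C)cc1` carries the change (methyl in place of trifluoromethoxy on an aromatic carbon). This again alters only the group at that position, and the expectation is no movement beyond the scatter, as seen in the step from compound 2 to compound 3 no change at the digits printed from compound 2 to compound 3 (within the scatter); the expected step is a number 1 percentage points higher from compound 3 to compound 4 (within the scatter). Compound 4 is therefore estimated at 2%, within 0% to 12%.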

Compound 4, a percentage reported as inhibition, at one concentration (the size of the read-out at that concentration, not a potency): 1%
Compound 4: middle estimate off by 1 percentage points, on the high side, and the stated range covers the measured number.
By their numbers in this assay, from the lowest: compounds 1, 2, 3 and 4 (each within the scatter of the next).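

Methyl, the first group here joined to the ring through carbon rather than oxygen, leaves this assay flat, with no change at the digits printed from compound 3 to compound 4 (within the scatter) and no change at the digits printed from compound 2 to compound 4 (within the scatter) and also no change at the digits printed from compound 1 to compound 4 (within the scatter). So removing the oxygen and the fluorines at this position, or the two chlorines of compound 1, brings no movement that these numbers can show. Nothing available explains this flatness. From the compounds shown here alone, whether an amine or a carboxylic acid at this position would raise the inhibition stays open. So does the effect of changing the rest of the shared core.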